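Working notes: butyl to propyl on compound 3

The source may hold more compounds than are shown below. What is called first, only, known or untested is meant among the compounds shown, and "the series" means these compounds.

Going by the values given here, the series so far holds three compounds tested in a functional assay on MCF7 cells (Homo sapiens) for antiproliferative activity, read by sulforhodamine B assay, with a stated time of 3 days; a lower number here means that less compound is needed, a higher number that more compound is needed for the effect. Compound 1 `CCCC1=C(OC)C(CCC)(CCC)C(=O)/C(=C(O)\C=C\c2ccccc2)C1=O` has no usable result, its entry reading "not determined" (no result reported). Compound 2 `CCCC1(CC=C(C)C)C(=O)C(C(=O)/C=C/c2ccccc2)=C(O)C(CCC)(CCC)C1=O` gives 5.8 uM, and compound 3 `CCCCOC1=C(CCC)C(=O)/C(=C(O)/C=C/c2ccccc2)C(=O)C1(CCC)CCC` gives 5.3 uM. These two numbers lie within the scatter of each other, so the data place compound 3 level with compound 2 and do not rank them. Among the compounds with values here, with only two numbers available, no trend can be drawn across the series.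

The next compound is compound 4 `CCCOC1=C(CCC)C(=O)/C(=C(O)/C=C/c2ccccc2)C(=O)C1(CCC)CCC`, which keeps the shared core of compound 3 and changes a single place: hydrogen in place of methyl on a saturated chain carbon, three bonds along the chain from an oxygen on an unsaturated carbon. The same difference reads as butyl to propyl, with hydrogen in place of methyl on a saturated chain carbon, three bonds along the chain from an oxygen on an unsaturated carbon.

Within the data shown here, no step between measured compounds that differ in one place is available, so the size of this change has no direct precedent. The expectation therefore starts from compound 3 at 5.3 uM, and no step beyond the scatter is expected in this assay, in either direction. The expected result is a 1.1-fold higher number from compound 3 to compound 4 (0.05 log units; within the scatter). Compound 4 is estimated at 6 uM, with an expected range of 3 uM to 12 uM.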

Compound 4, concentration for half-maximal effect: 1.6 uM
Beside the measured number, compound 4's estimate is 3.8-fold (0.57 log units) above it, outside the stated range (below it).
By their numbers in this assay, from the lowest: compound 4; then compounds 3 and 2 (each within the scatter of the next).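

In this assay, going by these compounds alone, butyl to propyl gives a 3.3-fold lower number from compound 3 to compound 4 (0.52 log units; beyond the scatter), and this is the first step between compounds that differ in one place. Within the data shown here, it shows that this position, on a saturated chain carbon, three bonds along the chain from an oxygen on an unsaturated carbon, is not silent: hydrogen in place of methyl there, with one carbon leaving and no ring, donor, acceptor or charge involved, moves the number beyond the scatter, which the earlier compounds could not show with no such pair among them. Nothing in hand explains why the number moves at this position.

On these data alone, a single step gives a direction for this one change and no trend along the chain, so it stays open whether an ethyl group in place of the propyl continues the fall, levels off or reverses it. Equally open, as far as these compounds go, is what a longer chain such as pentyl, or an amine or a carboxylic acid at the end of the chain, would do to the number at this position.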